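The compounds below may be only part of what the source reports. "The series", "measured", "known", "first", "only" and "open" are said of these compounds alone.

Compound 1 `COc1ccc(OCCCON2C(N)=NC(N)=NC23CCSCC3)cc1`: 350 nM
Compound 2 `NC1=NC2(CCSCC2)N(OCCCOc2cc(Cl)c(Cl)cc2Cl)C(N)=N1`: 110 nM
Compound 3 `NC1=NC2(CCSCC2)N(OCCCOc2ccccc2Cl)C(N)=N1`: 80 nM

In a functional assay on MDA-MB-231 cells (Homo sapiens) for antiproliferative activity, read by MTT assay, with a stated time of 72 h (on this read-out higher numbers stand for weaker inhibition and lower numbers for stronger inhibition), compound 3 gives the lowest of the three numbers, but compound 2 lies within the scatter of it, so the two cannot be ranked; only compound 1 stands clearly apart, with a 4.4-fold lower number from compound 1 to compound 3 (0.64 log units; beyond the scatter). Compound 4 `NC1=NC2(CCSCC2)N(OCCCOc2ccccc2Br)C(N)=N1` differs from compound 3 by bromo in place of chloro on an aromatic carbon. Among the measured compounds shown here, no measured step swaps one halogen for another; the steps that come closest change the aryl group as a whole. The step of a 1.4-fold lower number from compound 2 to compound 3 (0.14 log units; within the scatter) shows that removing two chloro groups from the ring left the number within the scatter, and a 3.2-fold lower number from compound 1 to compound 2 (0.50 log units; beyond the scatter) together with a 4.4-fold lower number from compound 1 to compound 3 (0.64 log units; beyond the scatter) shows that halogenated rings in this place give lower numbers than the methoxy ring. Nothing in the data separates bromo from chloro, so the step from compound 3 to compound 4 is expected to be no change at the digits printed from compound 3 to compound 4 (within the scatter), within the scatter. Compound 4 is therefore estimated at 80 nM, with a range from 40 nM to 160 nM.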

Compound 4, half-maximal inhibitory concentration: 10 nM
Beside the measured number, compound 4's estimate is 8.0-fold (0.90 log units) above it; the measured number lies below the stated range.
By their numbers in this assay, from the lowest: compound 4; then compounds 3 and 2 (each within the scatter of the next); then compound 1.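

In this assay the exchange of one halogen for another, on an aromatic carbon ortho to a large group, gives an 8.0-fold lower number from compound 3 to compound 4 (0.90 log units; beyond the scatter) and so does more than the earlier replacements of the whole aryl group did. The wider steps, an 11-fold lower number from compound 2 to compound 4 (1.04 log units; beyond the scatter) and a 35-fold lower number from compound 1 to compound 4 (1.54 log units; beyond the scatter), set the 2-bromophenyl group clearly apart from the other aryl groups shown, whereas compound 2 and compound 3 could not be ranked against each other. Nothing available gives a cause for the step from chloro to bromo.

The compounds shown leave open whether iodo, fluoro or methyl on the same aromatic carbon would continue or break this trend. They also leave open how bromo would fare elsewhere on the ring, and how a longer chain would behave with the 2-bromophenyl group in place.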